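Two carbonyls in place of one on the ring-fused amide

The source may hold more compounds than are shown below. What is called first, only, known or untested is meant among the compounds shown, and "the series" means these compounds.

Compound 1: `CC(C)(C)OC(=O)N(Cc1ccco1)C(=O)c1ccc(CN2Cc3ccccc3S2(=O)=O)cc1` — 10600 nM
Compound 2: `CC(C)(C)OC(=O)N(Cc1ccco1)C(=O)c1ccc(CN2Cc3ccccc3C2=O)cc1` — 51800 nM

In a functional assay on RAW264.7 cells (Mus musculus) for inhibition (a lower number here means a stronger inhibitor, a higher number a weaker inhibitor), compound 2 gives 51800 nM, the highest of the two numbers measured; its nearest neighbour is compound 1, with the step of a 4.9-fold higher number from compound 1 to compound 2 (0.69 log units; beyond the scatter). Compound 3 is `CC(C)(C)OC(=O)N(Cc1ccco1)C(=O)c1ccc(CN2C(=O)c3ccccc3C2=O)cc1`. It differs from compound 2 by a group of 11 heavy atoms (8 carbon, 1 nitrogen, 2 oxygen; one five-membered non-aromatic ring with 1 hetero atom, one six-membered aromatic ring of carbon only) in place of a group of 10 heavy atoms (8 carbon, 1 nitrogen, 1 oxygen; one five-membered non-aromatic ring with 1 hetero atom, one six-membered aromatic ring of carbon only), on a saturated chain carbon bound to an aromatic carbon. Within the data shown here, the only measured step that bears on this position is the one from compound 1 to compound 2, which exchanged one fused ring for another and was modest in size. The change to compound 3 restores a second hydrogen-bond acceptor on that ring, which brings it closer in count to compound 1 than compound 2 is. The expected step of a 1.7-fold lower number from compound 2 to compound 3 (0.24 log units; within the scatter) is therefore a small gain, though the scatter leaves room for none. Compound 3 is estimated at 30000 nM in this assay, with a range from 10000 nM to 100000 nM.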

Compound 3, half-maximal inhibitory concentration: 3450 nM
Compound 3: the middle estimate sits 8.7-fold (0.94 log units) above what was measured; the whole stated range lies above it.
By their numbers in this assay, from the lowest: compound 3; then compound 1; then compound 2.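

In this assay, among these compounds, the second carbonyl on the five-membered ring proves to matter far more than the single earlier step suggested: adding it gives a 15-fold lower number from compound 2 to compound 3 (1.18 log units; beyond the scatter) and reverses the order set by the first pair. The change also overtakes the sulfur-containing ring, with a 3.1-fold lower number from compound 1 to compound 3 (0.49 log units; beyond the scatter) and compound 3 now holding the lowest number of the three, so two carbonyls serve better at this position than the sulfur group does. Nothing measured here accounts for the size of this gain.

Going by these compounds, whether the gain belongs to this five-membered ring or would persist with both carbonyls in a six-membered ring or an open chain remains open. So does the effect of an amine or a fluorine on the six-membered aromatic ring of this group.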